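Tripyridyl hydroxyphenyl series: cytotoxicity in HEK293 cells

The compounds below may be only part of what the source reports. "The series", "measured", "known", "first", "only" and "open" are said of these compounds alone.

Compound 1 `Oc1ccc(-c2cc(-c3cccc(O)c3)nc(-c3ccccc3O)c2)cc1`: 7420 nM
Compound 2 `Oc1cccc(-c2cc(-c3ccccc3O)cc(-c3ccccc3O)n2)c1`: 730 nM
Compound 3 `Oc1cccc(-c2cc(-c3cccc(O)c3)nc(-c3ccccc3O)c2)c1`: > 50000 nM

In an ADME assay on HEK293 cells (Homo sapiens) for cytotoxicity, read by CCK-8 assay, with a stated time of 4 days (a lower number here means a stronger inhibitor, a higher number a weaker inhibitor), compound 2 gives the lowest of the two numbers shown; compound 1 is the nearest, with a 10-fold lower number from compound 1 to compound 2 (1.01 log units; beyond the scatter). Compound 3 is reported only as a limit, (the limit of > 50000 nM in this assay, at which 1 of the 3 values shown sits). Compound 4 `Oc1ccc(-c2cc(-c3ccccc3O)cc(-c3cccc(O)c3)n2)cc1` is not yet measured. It differs from compound 2 by 4-hydroxyphenyl in place of 2-hydroxyphenyl on an aromatic carbon. Within the data shown here, the step that bears on it is the reverse of the one from compound 1 to compound 2, where the same exchange in the opposite direction was large, a 10-fold lower number from compound 1 to compound 2 (1.01 log units; beyond the scatter). A large step to a higher number in this assay is therefore expected for compound 4, about a 9.6-fold higher number from compound 2 to compound 4 (0.98 log units; beyond the scatter). The estimate for compound 4 is 7000 nM, with a range from 2500 nM to 20000 nM.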

Compound 4, half-maximal inhibitory concentration: 5650 nM
Beside the measured number, compound 4's estimate is 1.2-fold (0.09 log units) above it; measured number inside the range.
By their numbers in this assay, from the lowest: compound 2; then compounds 4 and 1 (each within the scatter of the next). At a limit, above all of these: compound 3.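

In this assay, 4-hydroxyphenyl in place of 2-hydroxyphenyl on the carbon next to the ring nitrogen gives a 7.7-fold higher number from compound 2 to compound 4 (0.89 log units; beyond the scatter), beyond the scatter as printed. The other 2-hydroxyphenyl group of the core undergoes the same exchange in the reverse of a 10-fold lower number from compound 1 to compound 2 (1.01 log units; beyond the scatter), so both places move the number in the same direction in these compounds. Nothing given here accounts for either step.

Still open, from the compounds shown here alone, is how a methoxy group or an amine in place of the hydroxyl on this ring would read. Going by these compounds, the effect of a longer chain at this position also stays unknown.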